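Adding pyridin-4-yl to a compound at the solubility limit

The source may report more compounds than this note shows. Statements on the series, on what has been measured and on what is new or still open speak of the compounds shown alone.

Compound 1 `CCCOC(=O)c1nc(C)c2c(c1N)C(=O)N(Cc1ccccc1)C2=O`: < 5000 nM (a limit)
Compound 2 `Cc1nc(C(N)=O)c(N)c2c1C(=O)N(Cc1ccccc1)C2=O`: < 5000 nM (a limit)
Compound 3 `Cc1noc(-c2nc(C)c3c(c2N)C(=O)N(Cc2ccccc2)C3=O)n1`: < 5000 nM (a limit)

In a physicochemical assay for solubility, using the shake flask method, in simulated intestinal fluid, measured as kinetic solubility, with a stated time of 2 h, at 25 degrees C, at pH 6.5 (a lower number here means a less soluble compound, a higher number a more soluble compound), compound 3 gives < 5000 nM, which is a limit and not a number. It is not alone there, as the three compounds share (the limit of < 5000 nM in this assay, at which 3 of the 3 values shown sit).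

Compound 4 `Cc1noc(-c2nc(C)c3c(c2N)C(=O)N(Cc2ccc(-c4ccncc4)cc2)C3=O)n1` has pyridin-4-yl in place of hydrogen on an aromatic carbon of a six-membered aromatic ring of carbon only, para to a large group (pyridin-4-yl in place of hydrogen on an aromatic carbon).

Going by the values given here, none of the measured steps adds pyridin-4-yl. They are a step that the two limits leave unreadable from compound 1 to compound 2, a step that the two limits leave unreadable from compound 1 to compound 3 and a step that the two limits leave unreadable from compound 2 to compound 3. These steps offer no size to carry over, so compound 4 is expected to be reported most likely as a limit in this assay too. The estimated step is a step that the limit leaves unreadable from compound 3 to compound 4, and its direction remains uncertain. The estimated value for compound 4 is 3000 nM, with an expected range from 800 nM to 8000 nM.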

Compound 4, solubility: < 5000 nM
Compound 4 gave a limit, no number (the forecaster's own chance of this, stated with the estimate: 80%); the middle value is on the limit's open side.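

In this assay compound 4 gives < 5000 nM, a limit and not a number. Going by these compounds alone, with compound 3 at a limit too, no step between compound 3 and compound 4 can be read. Still open, from the compounds shown here alone, is how soluble any of the four compounds really is, and whether pyridin-4-yl in place of hydrogen shifts that value.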